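Moving the fluorine from one ring position to another

The compounds below may be only part of what the source reports. "The series", "measured", "known", "first", "only" and "open" are said of these compounds alone.

Measured compounds:
- compound 1, `COC(=O)C1=C(C)N=C(C)/C(=C(\O)OC)C1c1c(F)c(F)c(F)c(F)c1F`: 4.37 nM
- compound 2, `COC(=O)C1=C(C)N=C(C)/C(=C(\O)OC)C1c1ccccc1F`: 42.7 nM
- compound 3, `COC(=O)C1=C(C)N=C(C)/C(=C(/O)OC)C1c1cccc(Cl)c1`: 15.9 nM

All three share one core and differ only in the aryl group attached to the saturated ring carbon. In a functional assay (muscle tissue) with Cavia porcellus as the target (a lower number here means that less compound is needed, a higher number that more compound is needed for the effect), compound 2 gives 42.7 nM, the highest of the three numbers. Its nearest neighbour is compound 3 with 15.9 nM, a gap that lies beyond the scatter; compound 1 with 4.37 nM lies furthest away, also beyond the scatter. No pair among these three differs in only one place, so no single step has been measured.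

Compound 4 is `COC(=O)C1=C(C)N=C(C)/C(=C(\O)OC)C1c1cccc(F)c1`. Compared with compound 2 the change is 3-fluorophenyl in place of 2-fluorophenyl on a saturated ring carbon. The same atoms are present, joined differently. The comparison with compound 3, which also carries a halogen at the 3-position of the phenyl ring and gives a lower number than compound 2, suggests the step of a 2.5-fold lower number from compound 2 to compound 4 (0.40 log units; beyond the scatter) is expected to go downward, beyond the scatter. Compound 4 is therefore estimated at 17 nM, with a range from 6 nM to 50 nM.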

Compound 4, half-maximal effective concentration: 20.9 nM
Compound 4: middle estimate off by 1.2-fold (0.09 log units), on the low side; the measured number falls inside the stated range.
By their numbers in this assay, from the lowest: compound 1; then compounds 3 and 4 (each within the scatter of the next); then compound 2.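

Among these compounds, for the first time a single change can be read: in this assay there is a 2.0-fold lower number from compound 2 to compound 4 (0.31 log units; beyond the scatter). The leaving and entering groups count the same heavy atoms and the same single aromatic ring, so only the place of the fluorine on that ring separates the two compounds, and that alone is enough to shift the number beyond the scatter, though modestly. Nothing available here explains why this shift occurs.

Whether the fluorine helps at all remains open, since the comparison with a plain phenyl group is missing from the compounds shown. On these data alone, it is also open how this position responds to groups other than halogens, such as a nitro group or an amine on the phenyl ring.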